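This account rests on a few compounds, and the source may have more. Where it says the series, first, only, none or still open, it means among the compounds named here.

Going by the values given here, in a functional assay on MDA-MB-231 cells (Homo sapiens) for antiproliferative activity, read by sulforhodamine B assay, with a stated time of 48 h (a higher number here means a weaker inhibitor of growth, a lower number a stronger inhibitor of growth), two compounds built on one shared core have numbers so far. Compound 1 `COc1ccc(-c2cn(CCCN3C(=O)COc4ccccc43)nn2)cc1`, which carries 4-methoxyphenyl on an aromatic carbon, gives 41500 nM. Compound 2 `O=C1COc2ccccc2N1CCCn1cc(CO)nn1`, with hydroxymethyl in that place, gives 5700 nM, the lower of the two numbers and so the stronger inhibitor of growth.

The next compound, compound 3 `CCCc1cn(CCCN2C(=O)COc3ccccc32)nn1`, keeps everything in compound 2 except one detail: ethyl in place of hydroxy on a saturated chain carbon bound to an aromatic carbon. Put simply, the hydroxymethyl of compound 2 becomes propyl in compound 3.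

Among the compounds with values here, only one measured step bears on this, and only indirectly: a 7.3-fold lower number from compound 1 to compound 2 (0.86 log units; beyond the scatter). Within the data shown here, that step also involved hydroxymethyl, but no measured compound shows what a plain propyl does. Compound 3 resembles compound 2 in having no added ring, yet it loses the hydroxy, so a modest move towards weaker inhibition seems more likely than none. The expected step is a 2.5-fold higher number from compound 2 to compound 3 (0.39 log units; beyond the scatter). The estimated value for compound 3 is 14000 nM, with an expected range from 5000 nM to 40000 nM.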

Compound 3, concentration for 50% growth inhibition: 1100 nM
Beside the measured number, compound 3's estimate is 13-fold (1.10 log units) above it, and the stated range ends above it.
By their numbers in this assay, from the lowest: compound 3; then compound 2; then compound 1.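

In this assay the hydroxy group of compound 2 proves unnecessary at this place on a saturated chain carbon bound to an aromatic carbon: exchanging it for ethyl, which turns hydroxymethyl into propyl, gives a 5.2-fold lower number from compound 2 to compound 3 (0.71 log units; beyond the scatter) and so removes a hydrogen-bond donor and a hydrogen-bond acceptor with no loss in growth inhibition. Propyl also improves on 4-methoxyphenyl by more than hydroxymethyl did, with a 38-fold lower number from compound 1 to compound 3 (1.58 log units; beyond the scatter) and compound 3 now the strongest inhibitor of growth of the three, which shows that the earlier gain did not depend on keeping the hydroxy group. Nothing available explains why propyl gives the lowest number of the three.

The compounds shown leave open whether a longer chain such as butyl would lower the number further, or whether a shorter one such as methyl would keep the gain seen with propyl. They also leave open how an amine or a carboxylic acid at the end of this chain would compare with the hydroxy group of compound 2 and the plain carbon chain of compound 3.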